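Hydroxycyclohexyl for Hydroxypropyl: Permeability at the Limit

The compounds below may be only part of what the source reports. "The series", "measured", "known", "first", "only" and "open" are said of these compounds alone.

Measured compounds:
compound 1, `N=c1c2c(-c3ccccc3)c(-c3ccccc3)n(Cc3ccccc3)c2ncn1C1CCN(Cc2ccccc2)CC1`: "nd" (no result reported)
compound 2, `COc1ccc(Cn2c(-c3ccccc3)c(-c3ccccc3)c3c(=N)n(C4CCOCC4)cnc32)cc1`: "nd" (no result reported)
compound 3, `COc1ccc(-c2c(-c3ccc(OC)cc3)n(Cc3ccccc3)c3ncn(CCCO)c(=N)c23)cc1`: > 1000 10^-6 cm/s

In an ADME assay for permeability, using PAMPA, with a stated time of 30 min, at pH 7.4 (on this read-out higher numbers stand for higher permeability and lower numbers for lower permeability), compound 1 has no reported result, "nd" (no result reported). Compound 2 likewise has no result in this assay, "nd" (no result reported). For compound 3 the read-out is a limit of the assay and not a number, > 1000 10^-6 cm/s. Compound 3 is therefore the only one of the three with any figure at all, and that figure is the limit of > 1000 10^-6 cm/s in this assay, at which 1 of the 3 values shown sits. For the measured compounds named here, no pair of measured compounds differs in a single place, so no measured step is available.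

Compound 4, `COc1ccc(-c2c(-c3ccc(OC)cc3)n(Cc3ccccc3)c3ncn([C@H]4CC[C@H](O)CC4)c(=N)c23)cc1`, differs from compound 3 by 4-hydroxycyclohexyl in place of 3-hydroxypropyl on an aromatic nitrogen; in words, 4-hydroxycyclohexyl in place of 3-hydroxypropyl on an aromatic nitrogen. With compound 3 already at a limit, the expected step from compound 3 to compound 4 is none beyond the scatter, and compound 4 is expected most likely to return a limit again rather than a number. The estimate for compound 4 in this assay is 1000 10^-6 cm/s, with a range from 400 10^-6 cm/s to 1500 10^-6 cm/s, which means an expected step of a number no higher from compound 3 to compound 4 (the limit leaves the size open).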

Compound 4, apparent permeability: 196 10^-6 cm/s
For compound 4 the middle estimate is 5.1-fold (0.71 log units) above the measured one; the measured number lies below the stated range.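

Placing 4-hydroxycyclohexyl in place of 3-hydroxypropyl on the aromatic nitrogen gives, in this assay, an at least 5.1-fold lower number from compound 3 to compound 4 (0.70 log units; beyond the scatter), so the read-out at this position does respond to the group it carries. For the compounds shown here, the two groups have the same count of hydrogen-bond donors and acceptors and neither has a net charge, so these counts do not separate them; the entering group differs in its carbon ring, its larger number of heavy atoms and its two defined stereocentres, and compound 4 supplies the only actual number in this small set. The step gives a minimum and not a full size, because the value for compound 3 is a limit of the assay: the limit of > 1000 10^-6 cm/s in this assay, at which 1 of the 4 values shown sits.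

The compounds shown leave open whether the ring itself or simply the larger group accounts for the step, and how the opposite arrangement at the stereocentres of the 4-hydroxycyclohexyl group would read. They also leave open how an amine, a carboxylic acid or a longer hydroxyalkyl chain on this nitrogen would behave in this assay.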